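Methoxy count on the aryl ring and cytochrome inhibition

This account rests on a few compounds, and the source may have more. Where it says the series, first, only, none or still open, it means among the compounds named here.

Values in an assay for inhibition of cytochrome P450 1A1 (Homo sapiens), read by fluorescence, using microsomes, with a stated time of 10 min; on this read-out higher numbers stand for weaker inhibition and lower numbers for stronger inhibition:
- compound 1 `COc1ccccc1/C=C/C(=O)c1ccc[nH]1`: 900 nM
- compound 2 `COc1cc(/C=C/C(=O)c2ccc[nH]2)cc(OC)c1`: 6100 nM
- compound 3 `COc1cc(/C=C/C(=O)c2ccc[nH]2)cc(OC)c1OC` gives only a limit of the assay, > 20000 nM

Three compounds share the same enone-pyrrole portion and differ in the methoxy pattern on the aryl ring. Compound 1 carries the lowest of the two numbers, compound 2 a clearly higher one; the difference between the two cores is not broken down here. Among the measured compounds shown here, the one measured single-point step is an at least 3.2-fold higher number from compound 2 to compound 3 (0.51 log units; beyond the scatter), the change being (methoxy in place of hydrogen on an aromatic carbon). The step is a lower bound because compound 3 sits at the limit of > 20000 nM in this assay, at which 1 of the 3 values shown sits.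

Compound 4 `COc1cccc(OC)c1/C=C/C(=O)c1ccc[nH]1` is not yet measured in this assay. It relates to compound 1 by methoxy in place of hydrogen on an aromatic carbon. This is the same kind of change as that from compound 2 to compound 3, but not the same: in compound 4 the new methoxy stands ortho to a group of 9 heavy atoms and meta to a methoxy group, whereas in compound 3 it stands ortho to two methoxy groups and para to a group of 9 heavy atoms. Resting on the single measured step from compound 2 to compound 3, an added methoxy is expected to raise the number, so a step of a 3.3-fold higher number from compound 1 to compound 4 (0.52 log units; beyond the scatter) is estimated. For compound 4 a value of 3000 nM is expected, with a range from 1000 nM to 10000 nM.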

Compound 4, half-maximal inhibitory concentration: 10800 nM
For compound 4 the middle estimate is 3.6-fold (0.56 log units) below the measured one; measured number outside the range, above it.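

In this assay, methoxy in place of hydrogen on an aromatic carbon gives a 12-fold higher number from compound 1 to compound 4 (1.08 log units; beyond the scatter), a large step on the core of compound 1. Set beside the earlier step, the change raises the number on both cores, but how the two sizes compare stays unresolved: the same change on two cores in this assay, an at least 3.2-fold higher number (0.51 log units; beyond the scatter) from compound 2 to compound 3 and a 12-fold higher number (1.08 log units; beyond the scatter) from compound 1 to compound 4; the limit leaves it open whether they differ. Compound 3 gives only a limit of the assay, > 20000 nM, and the new methoxy stands at a different place on the ring in the two steps, so the direction of the change is seen twice, while a size that carries over from one core to another is not shown.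

From the compounds shown here alone, with only these two steps, it remains open whether the number follows the count of methoxy groups on the aryl ring or the places they occupy, and whether the direction would hold at other positions or on further cores. Also open, going by these compounds, is whether the rise belongs to methoxy itself or would appear with another group in the same place, such as hydroxy, fluoro, a dimethylamino group or a longer chain like ethoxy.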